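This account rests on a few compounds, and the source may have more. Where it says the series, first, only, none or still open, it means among the compounds named here.

Three compounds of one series share a long chain ending in a hydroxamic acid and have been tested in a functional assay on MM96L cells (Homo sapiens) for antiproliferative activity; on this read-out higher numbers stand for weaker inhibition and lower numbers for stronger inhibition. Compound 2 `O=C(CCCCC[C@H](NC(=O)OCc1ccccc1)C(=O)NCc1ccncc1)NO` gives 4320 nM. Compound 1 `O=C(CCCCC[C@H](NC(=O)c1ccc(Br)cc1)C(=O)NCc1ccncc1)NO` differs from it by 4-bromophenyl in place of benzyloxy on a carbonyl carbon, and in this assay compound 1 gives 830 nM, so that the step of a 5.2-fold lower number from compound 2 to compound 1 (0.72 log units; beyond the scatter). Compound 3 `O=C(CCCCC[C@H](NC(=O)OCc1ccccc1)C(=O)Nc1ccc(-c2ccccc2)cc1)NO` differs from compound 2 at another place, by 4-phenylphenyl in place of (pyridin-4-yl)methyl on an amide-type nitrogen, and in this assay compound 3 gives 330 nM, which is the lowest of the three numbers; the step is a 13-fold lower number from compound 2 to compound 3 (1.12 log units; beyond the scatter).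

Compound 4 `O=C(CCCCC[C@H](NC(=O)c1ccc(Br)cc1)C(=O)Nc1ccc(-c2ccccc2)cc1)NO` has not yet been measured. Within the data shown here, it differs from compound 3 by 4-bromophenyl in place of benzyloxy on a carbonyl carbon, which is the same change as the one that turns compound 2 into compound 1, made here on the core of compound 3 instead of the core of compound 2; the place where it is made is the same in both pairs. If the change repeats its earlier effect, the step from compound 3 to compound 4 is expected to be a 3.7-fold lower number from compound 3 to compound 4 (0.56 log units; beyond the scatter), somewhat tempered because the earlier step of a 5.2-fold lower number from compound 2 to compound 1 (0.72 log units; beyond the scatter) was seen only once, on the core of compound 2, and the two changes need not add fully. On that basis compound 4 is estimated to give 90 nM in this assay, with a likely range from 30 nM to 300 nM.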

Compound 4, half-maximal inhibitory concentration: 70 nM
Compound 4: the middle estimate sits 1.3-fold (0.11 log units) above what was measured; the range from low to high includes it.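

In this assay, putting 4-bromophenyl in place of benzyloxy on the carbonyl carbon gives a 4.7-fold lower number from compound 3 to compound 4 (0.67 log units; beyond the scatter), and this step agrees with the one seen earlier on the other core: the same change on two cores in this assay, a 5.2-fold lower number (0.72 log units; beyond the scatter) from compound 2 to compound 1 and a 4.7-fold lower number (0.67 log units; beyond the scatter) from compound 3 to compound 4, 1.1-fold (0.04 log units) apart, within the scatter of two such steps The change therefore carried over at about the same size on these two cores, even though one has (pyridin-4-yl)methyl on the amide-type nitrogen and the other has 4-phenylphenyl there. This is one pair of steps in one cell assay, so it does not show that the change would repeat on a third core, and it does not explain why the number falls.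

The swap replaces benzyloxy with 4-bromophenyl in a single move, so the compounds shown do not separate the part played by the bromine from that of the rest of the group; a plain phenyl or a 4-chlorophenyl on the same carbonyl carbon would address this. Also open, from the compounds shown here alone, is whether the step would hold with a shorter or longer chain leading to the hydroxamic acid.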